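The source may hold more compounds than are shown below. What is called first, only, known or untested is meant among the compounds shown, and "the series" means these compounds.

Working notes on the solubility series. In a physicochemical assay for solubility, at pH 2 (a lower number here means a less soluble compound, a higher number a more soluble compound), compound 1, `CNc1nc(NCCCN(C)C)c2oc(-c3ccccc3)cc2n1`, gives 214 ug/mL. Compound 2, `CNc1nc(NCCCN(C)C)c2cc(-c3ccccc3)sc2n1`, gives 216 ug/mL in this assay, a value within the scatter of that of compound 1. Compound 3, `CNc1nc(NCCCN(C)C)c2sc(-c3ccc(S(C)(=O)=O)cc3)cc2n1`, is reported in this assay only as a limit, > 100 ug/mL, and not as a number. Within the data shown here, the evidence at hand for compound 3 is the limit of > 100 ug/mL in this assay, at which 1 of the 3 values shown sits, so its standing on the numbers is open-ended: where it sits in this assay above that limit is not known, and no step to compound 1 or compound 2 can be stated.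

Compound 4, `CNc1nc(NCCCN(C)C)c2sc(-c3ccc(C(C)=O)cc3)cc2n1`, is not yet measured in this assay. Its difference from compound 3 is acetyl in place of methylsulfonyl on an aromatic carbon. Among the measured compounds shown here, no step between measured compounds covers this change, so nothing in the set shows its size. The step from compound 3 to compound 4 is expected to be a step that the limit leaves unreadable from compound 3 to compound 4, a small step that is not expected to pass beyond the scatter in either direction. Compound 4 is estimated to give about 150 ug/mL in this assay, with an expected range from 50 ug/mL to 400 ug/mL.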

Compound 4, solubility: > 100 ug/mL
Compound 4 ended at the assay's limit; the forecaster's own chance of this, stated with the estimate: 35%; the middle value is on the limit's open side.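

In this assay compound 4 is reported only as a limit, > 100 ug/mL, and not as a number. Among these compounds, no step between compound 3 and compound 4 can be read, as both stand at a limit: the limit of > 100 ug/mL in this assay, at which 2 of the 4 values shown sit. The compounds shown leave open where compound 3 and compound 4 sit relative to each other and to compound 1 and compound 2.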